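Cyclohexyl Gives Way to a Hydroxymethylfuran

This account rests on a few compounds, and the source may have more. Where it says the series, first, only, none or still open, it means among the compounds named here.

Compound 3 `O=c1[nH]/c(=C\C2CCCCC2)c(=O)[nH]/c1=C\c1cccc(Oc2ccc(F)cc2)c1` was tested in a functional assay on NCI-H460 cells (Homo sapiens) for cytotoxicity, read by MTT assay, with a stated time of 72 h; a lower number here means a stronger inhibitor, a higher number a weaker inhibitor. Compound 3 gives > 1000 nM, which is a limit of the assay and not a number. Compound 3 thus sits at the limit of > 1000 nM in this assay, at which 1 of the 3 values shown sits. Going by the values given here, for context, compound 1 `CC(C)(C)c1[nH]cnc1/C=c1\[nH]c(=O)/c(=C/c2cccc(C(=O)c3ccc(F)cc3)c2)[nH]c1=O` gives 3.8 nM, and compound 2 `Cc1[nH]cnc1/C=c1\[nH]c(=O)/c(=C/c2cccc(C(=O)c3ccc(F)cc3)c2)[nH]c1=O` gives 15.9 nM; the only measured step, a 4.2-fold higher number from compound 1 to compound 2 (0.62 log units; beyond the scatter), concerns a methyl in place of tert-butyl on an aromatic carbon and so does not touch the change at hand. Compound 4 `O=c1[nH]/c(=C\c2ccc(CO)o2)c(=O)[nH]/c1=C\c1cccc(Oc2ccc(F)cc2)c1` has not been measured. It differs from compound 3 by 5-(hydroxymethyl)furan-2-yl in place of cyclohexyl on a double-bonded chain carbon bound to an aromatic carbon. Among the compounds with values here, no measured step anchors this change directly; in compound 1 and compound 2 an aromatic ring on that chain carbon goes with low numbers, while the cyclohexyl of compound 3 goes with a limit, though the other side of the core also differs. The step from compound 3 to compound 4 is expected to be an at least 1.4-fold lower number from compound 3 to compound 4 (0.15 log units; that floor lies within the scatter), toward a lower number, with wide uncertainty. Compound 4 is estimated at 700 nM, within 120 nM to 4000 nM.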

Compound 4, half-maximal inhibitory concentration: 41.5 nM
Estimate against measurement, compound 4: 17-fold (1.23 log units) above, outside the stated range (below it).
By their numbers in this assay, from the lowest: compound 1; then compound 2; then compound 4. At a limit, above all of these: compound 3.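

The double-bonded chain carbon bound to an aromatic carbon responds strongly to what it carries: in this assay, 5-(hydroxymethyl)furan-2-yl in place of cyclohexyl, with the rest of the molecule unchanged, gives an at least 24-fold lower number from compound 3 to compound 4 (1.38 log units; beyond the scatter). Going by these compounds alone, compound 1 and compound 2 differ from compound 3 on the other side of the core as well, and only this pair isolates the change at this position. The step is a floor and not an exact size, since compound 3 stands at a limit of the assay and not at a number: the limit of > 1000 nM in this assay, at which 1 of the 4 values shown sits.

The furan ring and its hydroxymethyl enter together, and the pair cannot tell which of them accounts for the step. A plain furan-2-yl, or an amine or a carboxylic acid in place of the hydroxymethyl, would separate the two.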